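The source may report more compounds than this note shows. Statements on the series, on what has been measured and on what is new or still open speak of the compounds shown alone.

Measured so far in an assay on HEK293 cells for agonist activity at Toll-like receptor 8 (Homo sapiens), read by a luciferase reporter, with a stated time of 6 h; on this read-out lower numbers stand for an effect already at smaller amounts and higher numbers for an effect only at larger amounts of compound:
Compound 1 `CCCCNc1nc(N)nc2c1CN(Cc1ccncc1)CC2` gives 0.29 uM.
Compound 2 `CCCCNc1nc(N)nc2c1CN(Cc1ccco1)CC2` gives 0.08 uM.
Compound 3 `CCCCNc1nc(N)nc2c1CN(C(=O)CC)CC2` gives 0.4 uM.

Compound 3 carries the highest of the three numbers, but its gap from compound 1 is within the scatter, a 1.4-fold higher number from compound 1 to compound 3 (0.14 log units; within the scatter); only compound 2 stands clearly apart from it, a 5.0-fold higher number from compound 2 to compound 3 (0.70 log units; beyond the scatter). Compound 4 `CCCCNc1nc(N)nc2c1CN(C(=O)c1cnccn1)CC2` has not yet been measured. Its structural change relative to compound 3 is pyrazin-2-yl in place of ethyl on a carbonyl carbon; cut one bond further out, propanoyl becomes (pyrazin-2-yl)carbonyl. The measured steps that bear on it are those where an aromatic ring was traded against propanoyl on the amine nitrogen in the ring: a 1.4-fold higher number from compound 1 to compound 3 (0.14 log units; within the scatter) and a 5.0-fold higher number from compound 2 to compound 3 (0.70 log units; beyond the scatter). Going by the values given here, in both of those, however, the ring sat on a saturated chain carbon, whereas in compound 4 it sits on a carbonyl carbon, so no measured step matches the change closely. The two steps suggest that an aromatic ring at this position tends to lower the number relative to propanoyl, one of them beyond the scatter and one within it. One therefore expects for compound 4 a step of about a 1.6-fold lower number from compound 3 to compound 4 (0.20 log units; within the scatter), with uncertainty spanning no change to a modest improvement. The estimate for compound 4 in this assay is 0.25 uM, expected to fall between 0.08 uM and 0.8 uM.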

Compound 4, minimum effective concentration: 2.2 uM
The estimate for compound 4 lay 8.8-fold (0.94 log units) below the measured number; the measured number lies above the stated range.
By their numbers in this assay, from the lowest: compound 2; then compounds 1 and 3 (each within the scatter of the next); then compound 4.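

In this assay, pyrazin-2-yl in place of ethyl on a carbonyl carbon gives a 5.5-fold higher number from compound 3 to compound 4 (0.74 log units; beyond the scatter), so an aromatic ring at this place does not by itself go with a lower number. The direction is opposite to that of the furan-2-yl compound 2, which stands clearly lower than the propanoyl compound 3. The (pyrazin-2-yl)carbonyl group also stands clearly higher than both groups with a ring on a saturated chain carbon, with a 28-fold higher number from compound 2 to compound 4 (1.44 log units; beyond the scatter) and a 7.6-fold higher number from compound 1 to compound 4 (0.88 log units; beyond the scatter).

No measurement on these compounds gives a reason for the rise. They also leave the ring and the carbonyl unseparated, and a (pyrazin-2-yl)methyl group or a (furan-2-yl)carbonyl group on the amine nitrogen in the ring would tell which of the two goes with the higher number.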